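Chain homologation on a cytotoxicity series: compound 4 pending

This account rests on a few compounds, and the source may have more. Where it says the series, first, only, none or still open, it means among the compounds named here.

Three members of the series have been run in an ADME assay on HepG2 cells (Homo sapiens) for cytotoxicity, read by XTT assay, with a stated time of 48 h; on this read-out higher numbers stand for lower toxicity in this test and lower numbers for higher toxicity in this test. Compound 1 `CCCCCCCCCC[C@@H]1CC(O)=C(C(=O)CCC)C(=O)O1` gives 25 ug/mL. Compound 2 `CCCCCCCCCCC[C@@H]1CC(O)=C(C(=O)CCC)C(=O)O1` gives 19 ug/mL. Compound 3 `CCCCCCCCC[C@@H]1CC(O)=C(C(C)=O)C(=O)O1` gives 71 ug/mL, the highest of the three numbers, with its steps to compound 1 and compound 2 both beyond the scatter. The difference between the core of compound 1 and the core of compound 3 is not broken down here.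

Compound 2 differs from compound 1 by methyl in place of hydrogen on a saturated chain carbon, ten or more bonds along the chain from a saturated ring carbon. In this assay this change gave a 1.3-fold lower number from compound 1 to compound 2 (0.12 log units; within the scatter), a step within the scatter.

Compound 4 `CCCCCCCCC[C@@H]1CC(O)=C(C(=O)CC)C(=O)O1` has not yet been run. It differs from compound 3 by methyl in place of hydrogen on a saturated chain carbon bound to a carbonyl carbon. This is the same kind of change as that from compound 1 to compound 2, but the place is not the same: here the methyl enters on a saturated chain carbon bound to a carbonyl carbon. The two earlier changes and the one counted here are the only occurrences of this change among the compounds shown.

Going by the values given here, because compound 3 gives 71 ug/mL and because the one measured instance of this kind of change produced a 1.3-fold lower number from compound 1 to compound 2 (0.12 log units; within the scatter), a small step is expected, and compound 4 is expected to show a 1.3-fold lower number from compound 3 to compound 4 (0.11 log units; within the scatter). Compound 4 is thus estimated at 55 ug/mL, within a range from 28 ug/mL to 110 ug/mL.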

Compound 4, half-maximal cytotoxic concentration: 50 ug/mL
Compound 4: middle estimate off by 1.1-fold (0.04 log units), on the high side, within the range that was stated.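

In this assay, methyl in place of hydrogen on a saturated chain carbon bound to a carbonyl carbon gives a 1.4-fold lower number from compound 3 to compound 4 (0.15 log units; within the scatter), and the two instances of this kind of change agree: the same change on two cores in this assay, a 1.3-fold lower number (0.12 log units; within the scatter) from compound 1 to compound 2 and a 1.4-fold lower number (0.15 log units; within the scatter) from compound 3 to compound 4, 1.1-fold (0.03 log units) apart, within the scatter of two such steps. Within these two pairs, the addition of one methyl therefore carries from the core of compound 1 to the core of compound 3 without a step that stands out from the scatter, even though the methyl enters at a different place in each pair. This does not show that the methyl has a real effect of its own in either core, since both steps are small enough to be repeat variation, and two pairs in a single assay give no general rule for the series.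

The compounds shown leave open whether a longer chain in place of propanoyl, or a polar group such as an amine or a carboxylic acid at the end of either chain, would give a step beyond the scatter. They also leave open whether the same methyl change stays this small at other saturated chain carbons or on any further core.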